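This account rests on a few compounds, and the source may have more. Where it says the series, first, only, none or still open, it means among the compounds named here.

The measured compounds:
Compound 1, `CN/N=C/c1ccc2ccc(=O)oc2c1`: 6.9%
Compound 2, `CO/N=C/c1ccc2ccc(=O)oc2c1`: 21.9%
Compound 3, `O=c1ccc2ccc(/C=N/c3ccccc3)cc2o1`: 26.1%

All three numbers come from a functional assay for inhibition of beta-glucuronidase (Bos taurus), tested at 0.1 mM; a lower number here means a weaker effect, a higher number a stronger effect of the compound at the concentration tested. Compound 2 stands second highest of the three. Its nearest neighbour is compound 3 at 26.1%; the step of a number 4.2 percentage points higher from compound 2 to compound 3 (within the scatter) lies within the scatter, so these two cannot be put in order. The step from the lowest value, a number 15 percentage points higher from compound 1 to compound 2 (beyond the scatter), lies beyond the scatter. The three compounds share one core and differ only in the group on the double-bonded nitrogen.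

Compound 4, `CC(O)Cc1ccc2ccc(=O)oc2c1`, has not yet been measured in this assay. Its change from compound 2: a group of 4 heavy atoms (3 carbon, 1 oxygen; no ring) in place of a group of 4 heavy atoms (2 carbon, 1 nitrogen, 1 oxygen; no ring), on an aromatic carbon. Within the data shown here, no measured step exchanges the whole group on this aromatic carbon, so none bears on it directly. Among the measured compounds shown here, the only guide is how far the numbers moved when the group at this position was altered: a number 15 percentage points higher from compound 1 to compound 2 (beyond the scatter) and a number 19.2 percentage points higher from compound 1 to compound 3 (beyond the scatter) were both modest, while a number 4.2 percentage points higher from compound 2 to compound 3 (within the scatter) stayed within the scatter. A modest step in either direction, or none beyond the scatter, is therefore expected in this assay. Compound 4 is estimated at 18%, with a range from 4% to 36%. This estimate means an expected step of a number 3.9 percentage points lower from compound 2 to compound 4 (within the scatter).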

Compound 4, a percentage reported as inhibition, at one concentration (the size of the read-out at that concentration, not a potency): 7.5%
Compound 4: middle estimate off by 10.5 percentage points, on the high side; the measured number falls inside the stated range.
By their numbers in this assay, from the lowest: compounds 1 and 4 (each within the scatter of the next); then compounds 2 and 3 (each within the scatter of the next).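

Among these compounds, until now, every group on this aromatic carbon in this assay carried a double-bonded nitrogen, and the 2-hydroxypropyl group of compound 4 is the first that has no nitrogen and no double bond outside the aromatic rings. Exchanging the whole group gives a number 14.4 percentage points lower from compound 2 to compound 4 (beyond the scatter) and shows that a group of the same heavy-atom count can still shift the read-out beyond the scatter, so matching size in that simple count does not guarantee a matching number. The other comparison gives a number 0.6 percentage points higher from compound 1 to compound 4 (within the scatter) and places compound 4 and compound 1 within the scatter of each other, and no measurement shown here accounts for this pattern.

On these data alone, it remains open whether the hydroxyl of the 2-hydroxypropyl group contributes anything, which a plain propyl chain on the same aromatic carbon would help to settle, and how a primary amine or a carboxylic acid at that place would read. With only one read-out at a single concentration, these numbers show a stronger or weaker effect at that concentration and nothing more.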